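Swapping 4-Nitrophenyl for 3-Cyanophenyl: an Expected Weak Cytotoxic

The source may hold more compounds than are shown below. What is called first, only, known or untested is meant among the compounds shown, and "the series" means these compounds.

Compound 1 `O=c1ccoc2cc(OCc3cn(Cc4ccc([N+](=O)[O-])cc4)nn3)ccc12` is the starting point. In a functional assay on HeLa cells (Homo sapiens) for cytotoxicity, read by MTT assay, with a stated time of 48 h (a lower number here means a stronger inhibitor, a higher number a weaker inhibitor), compound 1 gives 25700 nM, the highest of the two plain numbers shown. Compound 2 `Cc1ccccc1Cn1cc(COc2ccc3c(=O)ccoc3c2)nn1` carries 2-methylphenyl where compound 1 carries 4-nitrophenyl; in this assay compound 2 gives 15300 nM, and the step of a 1.7-fold lower number from compound 1 to compound 2 (0.23 log units; within the scatter) stays inside the usual scatter. Compound 3 `O=c1ccoc2cc(OCc3cn(Cc4ccccc4F)nn3)ccc12` carries 2-fluorophenyl on the same saturated chain carbon. For compound 3 this assay reports only a limit, > 100000 nM, so the steps of an at least 3.8-fold higher number from compound 1 to compound 3 (0.59 log units; beyond the scatter) and an at least 6.5-fold higher number from compound 2 to compound 3 (0.81 log units; beyond the scatter) are lower bounds on a weakening.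

Compound 4 `N#Cc1cccc(Cn2cc(COc3ccc4c(=O)ccoc4c3)nn2)c1` has not yet been measured. Compared with compound 1 the change is 3-cyanophenyl in place of 4-nitrophenyl on a saturated chain carbon bound to an aromatic nitrogen. The two measured steps that bear on this are the swaps of the same 4-nitrophenyl on the same chain carbon: one changed nothing beyond the scatter, the other weakened the compound by at least a modest amount. The step from compound 1 to compound 4 is therefore expected to be a 1.4-fold higher number from compound 1 to compound 4 (0.13 log units; within the scatter), that is no clear change or a small weakening. Compound 4 is estimated to give 35000 nM in this assay, within a range from 12000 nM to 100000 nM.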

Compound 4, half-maximal inhibitory concentration: > 100000 nM
Compound 4 ended at the assay's limit; the forecaster's own chance of this, stated with the estimate: 30%; middle value at least 2.8-fold (0.45 log units) from the limit.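

Compound 4 gives a second case, after compound 3, in which replacing 4-nitrophenyl at this saturated chain carbon bound to an aromatic nitrogen weakens the compound in this assay, with the step printed as (an at least 3.8-fold higher number from compound 1 to compound 4 (0.59 log units; beyond the scatter)) and the comparison with the other measured compound as (an at least 6.5-fold higher number from compound 2 to compound 4 (0.81 log units; beyond the scatter)). The weakening therefore does not belong to 2-fluorophenyl alone, although compound 2 goes against any general rule, since its 2-methylphenyl stays within the scatter of the 4-nitrophenyl of compound 1 and remains the better measured partner for both weak compounds. Compound 3 and compound 4 cannot be placed in order, and the step between them cannot be read, because both stop at the top of the measurable range: the limit of > 100000 nM in this assay, at which 2 of the 4 values shown sit.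

Going by these compounds, how far compound 3 and compound 4 really lie beyond that limit stays unknown, so the four compounds give only a coarse split into two that register near the measured values and two that do not. On these data alone, whether an amine or a carboxylic acid on the phenyl ring, or a longer chain in place of the single saturated carbon, would bring a clear gain over compound 1 remains open.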